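The source may hold more compounds than are shown below. What is called first, only, known or untested is meant among the compounds shown, and "the series" means these compounds.

Compound 1 `Cc1ccc(NS(=O)(=O)c2ccc(N3CCNC3=O)cc2)cc1` gives 260 nM
Compound 2 `Cc1ccc(NS(=O)(=O)c2ccc(N3CCNC3=O)cc2)cc1C` gives 94 nM
Compound 3 `CCc1ccc(NS(=O)(=O)c2ccc(N3CCNC3=O)cc2)cc1` gives 480 nM

These values come from a functional assay on M21 cells (Homo sapiens) for antiproliferative activity, read by sulforhodamine B assay, with a stated time of 48 h; on this read-out lower numbers stand for stronger inhibition and higher numbers for weaker inhibition. Compound 3 stands level with compound 1 within the scatter, with a 1.8-fold higher number from compound 1 to compound 3 (0.27 log units; within the scatter), and on the weaker side of compound 2, with a 5.1-fold higher number from compound 2 to compound 3 (0.71 log units; beyond the scatter).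

Next is compound 4 `O=C1NCCN1c1ccc(S(=O)(=O)Nc2ccc(OC(F)F)cc2)cc1`, with difluoromethoxy in place of ethyl on an aromatic carbon, para to a large group: difluoromethoxy in place of ethyl on an aromatic carbon.

For the measured compounds named here, no measured compound carries difluoromethoxy. The nearest guides are the modest 2.8-fold lower number from compound 1 to compound 2 (0.44 log units; beyond the scatter) and the step to compound 3 given above, so no large change is expected in this assay. The expected result is a 1.4-fold lower number from compound 3 to compound 4 (0.14 log units; within the scatter), essentially no shift beyond the scatter. For compound 4 the estimate is 350 nM, with an expected range from 130 nM to 950 nM.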

Compound 4, half-maximal inhibitory concentration: 410 nM
For compound 4 the middle estimate is 1.2-fold (0.07 log units) below the measured one; the range from low to high includes it.
By their numbers in this assay, from the lowest: compound 2; then compounds 1, 4 and 3 (each within the scatter of the next).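

Difluoromethoxy, on an aromatic carbon para to a large group, reads level with ethyl (a 1.2-fold lower number from compound 3 to compound 4 (0.07 log units; within the scatter)) and also with methyl (a 1.6-fold higher number from compound 1 to compound 4 (0.20 log units; within the scatter)). This position therefore accepts a group holding oxygen and fluorine in place of these carbon substituents with no shift beyond the scatter. No available evidence explains this result. As far as these compounds go, whether an amine or a carboxylic acid at this position would also stay level remains open, as does how difluoromethoxy would read on the 3,4-dimethylphenyl pattern of compound 2.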